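Chain length at the acid end of the shared core

The source may report more compounds than this note shows. Statements on the series, on what has been measured and on what is new or still open speak of the compounds shown alone.

Measured compounds:
- compound 1, `O=C(O)CCC/C=C\C[C@@H]1CN(S(=O)(=O)c2cccc3ccccc23)C[C@@H]1c1ccccc1O`, 6.31 nM
- compound 2, `O=C(O)CC/C=C\C[C@@H]1CN(S(=O)(=O)c2ccc(Cl)cc2)C[C@H]1c1ccccc1O`, 12.6 nM

Both compounds were run in a functional assay (Cavia porcellus) for antagonist activity at thromboxane A2 receptor (Homo sapiens); on this read-out lower numbers stand for tighter binding and higher numbers for weaker binding. Compound 1 gives the lowest of the two numbers, 6.31 nM; compound 2, with 12.6 nM, sits a short way above it, and the gap between the two lies within the usual scatter, so nothing can be said about an order between them.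

Compound 3, `O=C(O)CC/C=C\C[C@@H]1CN(S(=O)(=O)c2cccc3ccccc23)C[C@@H]1c1ccccc1O`, has not yet been measured. It keeps the sulfonyl aryl and the stereochemistry of compound 1; the difference is carboxy in place of carboxymethyl on a saturated chain carbon, two bonds along the chain from a double-bonded chain carbon. Read one bond further out, this is 3-carboxypropyl to 2-carboxyethyl on the chain.

Compound 2 already carries the shorter chain, and its number against compound 1 stays within the scatter, although it also differs in the sulfonyl aryl and the stereochemistry, so it is not a clean guide. For compound 3, no step beyond the scatter is expected, with the estimated change a 1.3-fold higher number from compound 1 to compound 3 (0.10 log units; within the scatter) leaning only slightly toward a higher number. The estimate for compound 3 is 8 nM, within the range 3 nM to 25 nM.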

Compound 3, dissociation constant: 1.59 nM
The estimate for compound 3 lay 5.0-fold (0.70 log units) above the measured number; the measured number lies below the stated range.
By their numbers in this assay, from the lowest: compound 3; then compounds 1 and 2 (each within the scatter of the next).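

With the sulfonyl aryl and the stereochemistry held fixed, the chain length at the acid end proves to matter in this assay: 3-carboxypropyl to 2-carboxyethyl on the chain gives a 4.0-fold lower number from compound 1 to compound 3 (0.60 log units; beyond the scatter), a step beyond the scatter. The earlier pair could not show this, as compound 1 and compound 2 differ in more than the chain and their values stay within the scatter of each other; this single clean pair shows that carboxy in place of carboxymethyl at this saturated chain carbon is not a neutral change, though one pair in one direction does not make a trend. Nothing at hand bears on why the number falls with this change.

Still open, on these data alone, is whether the number keeps falling with a shorter chain, such as 2-carboxyethyl cut back to carboxymethyl in the same place, or whether a tetrazole or a primary amide can stand in for the carboxylic acid at the chain end. As far as these compounds go, it is also open whether the same shortening gives a step of similar size with the sulfonyl aryl and stereochemistry of compound 2.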